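Exchanging the Five-Membered Ring on a Shared Core

The compounds below may be only part of what the source reports. "The series", "measured", "known", "first", "only" and "open" are said of these compounds alone.

Measured compounds:
compound 1 `O=C(/C=C/c1ccsc1)c1cc(O)c(O)c([N+](=O)[O-])c1`: 230 nM
compound 2 `O=C(/C=C/c1ccoc1)c1cc(O)c(O)c([N+](=O)[O-])c1`: 290 nM

In an assay for inhibition of Catechol O-methyltransferase (Rattus norvegicus), read by fluorescence and spectrophotometry (on this read-out lower numbers stand for stronger inhibition and higher numbers for weaker inhibition), compound 2 gives 290 nM. Compound 1 gives 230 nM, and the two numbers lie within the scatter of each other, so neither compound can be set apart from the other on this read-out. Compound 3 `O=C(/C=C/c1nccs1)c1cc(O)c(O)c([N+](=O)[O-])c1` is not yet measured; it differs from compound 2 by 1,3-thiazol-2-yl in place of furan-3-yl on a double-bonded chain carbon bound to a double-bonded chain carbon. Among the measured compounds shown here, the only measured step that bears on this change is the exchange of one five-membered ring for another, a 1.3-fold higher number from compound 1 to compound 2 (0.10 log units; within the scatter), which did not move the number beyond the scatter. One exchange of this kind is a thin basis, yet it is the only one available, and on it a step of no more than scatter size is expected for compound 3, a 1.1-fold higher number from compound 2 to compound 3 (0.04 log units; within the scatter). Compound 3 is therefore estimated at 320 nM, with a range from 120 nM to 850 nM.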

Compound 3, half-maximal inhibitory concentration: 240 nM
Beside the measured number, compound 3's estimate is 1.3-fold (0.12 log units) above it; the measured number falls inside the stated range.
By their numbers in this assay, from the lowest: compounds 1, 3 and 2 (each within the scatter of the next).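

Placing a ring with two hetero atoms on the double-bonded chain carbon bound to a double-bonded chain carbon widens the exchange beyond the earlier pair: in this assay, 1,3-thiazol-2-yl in place of furan-3-yl gives a 1.2-fold lower number from compound 2 to compound 3 (0.08 log units; within the scatter), and 1,3-thiazol-2-yl in place of thiophen-3-yl gives a 1.0-fold higher number from compound 1 to compound 3 (0.02 log units; within the scatter). Across these three five-membered aromatic rings, a change in the identity and count of the hetero atoms, including the entry of a ring nitrogen, thus leaves all the numbers within the scatter of each other. No supporting measurement accounts for this result.

All three groups are five-membered aromatic rings, so the compounds shown do not tell how the number would respond to a phenyl ring, a pyridine ring, an amine or a longer chain at this place.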